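Swapping the piperazine substituent from cyclohexyl to neopentyl

The source may hold more compounds than are shown below. What is called first, only, known or untested is meant among the compounds shown, and "the series" means these compounds.

Measured compounds:
compound 1 `Cn1c(-c2ccc(Cl)cc2)c(CCC(=O)N2CCN(Cc3ccccc3)CC2)c2cc(Cl)ccc21`, 0.3 nM;
compound 2 `Cn1c(-c2ccc(Cl)cc2)c(CCC(=O)N2CCN(C3CCCCC3)CC2)c2cc(Cl)ccc21`, 0.35 nM.

Compound 2 holds the highest number of the two in an assay on CHO cells with Substance-P receptor (Homo sapiens) as the target (a higher number here means a weaker inhibitor, a lower number a stronger inhibitor), but its nearest neighbour is compound 1, and the step of a 1.2-fold higher number from compound 1 to compound 2 (0.07 log units; within the scatter) lies within the scatter. Compound 3 `Cn1c(-c2ccc(Cl)cc2)c(CCC(=O)N2CCN(CC(C)(C)C)CC2)c2cc(Cl)ccc21` differs from compound 2 in one place: neopentyl in place of cyclohexyl on an amine nitrogen in a ring. For the measured compounds named here, the only measured step at this amine nitrogen, a 1.2-fold higher number from compound 1 to compound 2 (0.07 log units; within the scatter), was small, so a change of similar size is expected here, with at most a slight rise. Compound 3 is therefore estimated at 0.6 nM (range 0.2 nM to 2 nM), a step of a 1.7-fold higher number from compound 2 to compound 3 (0.23 log units; within the scatter).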

Compound 3, half-maximal inhibitory concentration: 2 nM
Estimate against measurement, compound 3: 3.3-fold (0.52 log units) below; low and high end bracket the measured number.
By their numbers in this assay, from the lowest: compounds 1 and 2 (each within the scatter of the next); then compound 3.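

In this assay the substituent on this amine nitrogen turns out to matter: neopentyl in place of cyclohexyl gives a 5.7-fold higher number from compound 2 to compound 3 (0.76 log units; beyond the scatter) and tert-butyl in place of phenyl on the saturated chain carbon gives a 6.7-fold higher number from compound 1 to compound 3 (0.82 log units; beyond the scatter) whereas benzyl and cyclohexyl had stayed within the scatter of each other. Compounds 1 and 2 carry a ring in this group and compound 3 carries none, but a single compound cannot show whether the ring itself counts. Nothing available explains this step. Open, going by these compounds, is whether a cyclopentyl group would stay with benzyl and cyclohexyl, and whether a methyl group or a straight butyl chain would stand with neopentyl or beyond it.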